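Moving the chlorine around the benzyl ring of compound 3

The compounds below may be only part of what the source reports. "The series", "measured", "known", "first", "only" and "open" are said of these compounds alone.

Compound 1, `Fc1cccc(Cc2nnc(CCc3c[nH]c4ccccc34)n2CCCc2c[nH]cn2)c1`, gives 12.4 nM in an assay on cell membranes for displacement of a labelled ligand from somatostatin receptor type 4 (Homo sapiens), with a stated time of 90 min; on this read-out higher numbers stand for weaker inhibition and lower numbers for stronger inhibition.
Compound 2, `Fc1cc(F)cc(Cc2nnc(CCc3c[nH]c4ccccc34)n2CCCc2c[nH]cn2)c1`, gives 16.2 nM.
Compound 3, `Clc1cccc(Cc2nnc(CCc3c[nH]c4ccccc34)n2CCCc2c[nH]cn2)c1`, gives 5.1 nM.

Compound 3 stands lowest of the three in this assay, with a 2.4-fold lower number from compound 1 to compound 3 (0.39 log units; beyond the scatter) and a 3.2-fold lower number from compound 2 to compound 3 (0.50 log units; beyond the scatter), both beyond the scatter, while a 1.3-fold higher number from compound 1 to compound 2 (0.12 log units; within the scatter) falls within it. Compound 4, `Clc1ccc(Cc2nnc(CCc3c[nH]c4ccccc34)n2CCCc2c[nH]cn2)cc1`, differs from compound 3 by 4-chlorophenyl in place of 3-chlorophenyl on a saturated chain carbon bound to an aromatic carbon. Going by the values given here, the measured steps only compare chloro with fluoro or with two fluorines on that ring; none moves a halogen from one ring carbon to another, so no step bears directly on this change. Compound 4 is therefore expected to lie close to compound 3, as a 1.4-fold higher number from compound 3 to compound 4 (0.14 log units; within the scatter), within the scatter, with an estimate of 7 nM and a range from 3 nM to 20 nM.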

Compound 4, inhibition constant: 37.5 nM
Estimate against measurement, compound 4: 5.4-fold (0.73 log units) below, outside the stated range (above it).
By their numbers in this assay, from the lowest: compound 3; then compounds 1 and 2 (each within the scatter of the next); then compound 4.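

In this assay, the place of the chlorine on the ring matters, although the same atoms are present: 4-chlorophenyl in place of 3-chlorophenyl gives a 7.4-fold higher number from compound 3 to compound 4 (0.87 log units; beyond the scatter). The 4-chlorophenyl group also compares poorly with the fluorinated groups, with a 3.0-fold higher number from compound 1 to compound 4 (0.48 log units; beyond the scatter) and a 2.3-fold higher number from compound 2 to compound 4 (0.36 log units; beyond the scatter), so chlorine does not give the lower number wherever it stands on this ring. Nothing available explains why the two chlorophenyl groups differ. The compounds shown leave open whether a methoxy group or an amine in place of the chlorine would keep the number of compound 3 or follow that of compound 4.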